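Replacing the trifluoromethylphenyl ether of compound 2

The compounds below may be only part of what the source reports. "The series", "measured", "known", "first", "only" and "open" are said of these compounds alone.

Of the compounds shown here, three built on one shared acid-bearing core have been tested in a functional assay on cells for agonist activity at Free fatty acid receptor 1 (Mus musculus), read by FLIPR and calcium flux, with a stated time of 100 s; on this read-out higher numbers stand for an effect only at larger amounts of compound and lower numbers for an effect already at smaller amounts. Compound 1 `O=C(O)C[C@@H]1CCN1c1ccc(OCc2ccc(Cl)cc2Cl)cc1` gives 440 nM. Compound 2 `O=C(O)C[C@@H]1C[C@H](C(F)(F)F)CN1c1ccc(Oc2ccccc2C(F)(F)F)cc1` gives 1300 nM, the highest of the three numbers. Compound 3 `O=C(O)C[C@@H]1C[C@H](C(F)(F)F)CN1c1ccc(Oc2ccccc2OC(F)(F)F)cc1` gives 740 nM. Within the data shown here, the only pair that differs in a single place shows a 1.8-fold lower number from compound 2 to compound 3 (0.24 log units; within the scatter), a move within the scatter. Compound 1 differs from compound 2 in more than one place, and its number lies a little further away, beyond the scatter.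

Compound 4 `Cc1cccc(C)c1Oc1ccc(N2C[C@@H](C(F)(F)F)C[C@H]2CC(=O)O)cc1` has not yet been measured in this assay. It differs from compound 2 in one place: 2,6-dimethylphenyl in place of 2-(trifluoromethyl)phenyl on an oxygen on an aromatic ring. Among the measured compounds shown here, the one measured step that bears on this region is a 1.8-fold lower number from compound 2 to compound 3 (0.24 log units; within the scatter); it altered a single group on that ring and stayed small. For the measured compounds named here, no measured step exchanges the whole ring, so the change in compound 4 reaches further than anything already tested. Because a 1.8-fold lower number from compound 2 to compound 3 (0.24 log units; within the scatter) stayed within the scatter, a step of modest size in either direction is the most that is expected here. Compound 4 is therefore estimated to give about 900 nM, with a likely range from 300 nM to 2700 nM. That estimate would amount to a 1.4-fold lower number from compound 2 to compound 4 (0.16 log units; within the scatter), an expectation rather than a result.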

Compound 4, half-maximal effective concentration: 270 nM
The estimate for compound 4 lay 3.3-fold (0.52 log units) above the measured number; measured number outside the range, below it.
By their numbers in this assay, from the lowest: compounds 4, 1, 3 and 2 (each within the scatter of the next, the first and the last beyond it).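

In this assay, among these compounds, the change gives a 4.8-fold lower number from compound 2 to compound 4 (0.68 log units; beyond the scatter), the first step on this ring that lies beyond the scatter; the earlier step, a 1.8-fold lower number from compound 2 to compound 3 (0.24 log units; within the scatter), altered only a single group and stayed within it. The result therefore shows that the ring on this oxygen can shift the amount of compound needed for an effect, and that a carbon-only 2,6-dimethylphenyl ring is accepted here in place of the fluorine-bearing 2-(trifluoromethyl)phenyl ring. Two things change together in this one step, as the trifluoromethyl group leaves and two methyl groups enter, and no measurement is available to explain why the number fell.

The compounds shown leave open whether one methyl group on this ring would be enough or both are needed, a question that a plain 2-methylphenyl ring could address. They also leave open whether the two methyl groups matter as methyl groups at all, which a 2,6-dichlorophenyl ring on the same oxygen would help to test.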